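This account rests on a few compounds, and the source may have more. Where it says the series, first, only, none or still open, it means among the compounds named here.

Two compounds share a core built from a chlorinated aromatic ring carrying an oxyacetic acid and a carbon-carbon triple bond. In an assay on CHO cells for displacement of a labelled ligand from prostaglandin D2 receptor 2 (Homo sapiens), read by scintillation counting (on this read-out lower numbers stand for stronger inhibition and higher numbers for weaker inhibition), compound 1 `O=C(O)COc1ccc(Cl)cc1C#Cc1ccc(CO)cc1F` gives 28 nM, while compound 2 `O=C(O)COc1ccc(Cl)cc1C#Cc1ccncc1` gives 601 nM. Compound 2 therefore holds the higher of the two numbers, and the gap to compound 1 lies well beyond the usual scatter.

Compound 3 `Cc1ncccc1C#Cc1cc(Cl)ccc1OCC(=O)O` differs from compound 2 in one place: 2-methylpyridin-3-yl in place of pyridin-4-yl on a triple-bonded carbon. Among the measured compounds shown here, no measured pair describes such a swap, so the size of the step is open. Since both compounds keep one aromatic nitrogen and compound 2 gives 601 nM, a change of limited size in either direction is the most plausible outcome, with a mild improvement slightly favoured. For compound 3 the expected step is a 2.0-fold lower number from compound 2 to compound 3 (0.30 log units; within the scatter). Compound 3 is thus estimated at 300 nM, with a range from 60 nM to 1500 nM.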

Compound 3, inhibition constant: 143 nM
Beside the measured number, compound 3's estimate is 2.1-fold (0.32 log units) above it; the measured number falls inside the stated range.
By their numbers in this assay, from the lowest: compound 1; then compound 3; then compound 2.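

In this assay, putting 2-methylpyridin-3-yl in place of pyridin-4-yl on a triple-bonded carbon gives a 4.2-fold lower number from compound 2 to compound 3 (0.62 log units; beyond the scatter), a modest step. This position therefore responds to a change of the attached ring even though both groups are six-membered aromatic rings with 1 hetero atom and neither carries a net charge. It is also the only step among the compounds shown that can be read as a single change.

The swap both shifts the point of attachment from the 4-yl to the 3-yl position and adds a methyl group, and the compounds shown do not separate these two changes; a plain pyridin-3-yl group would stand between them. Nothing available here explains the size or direction of the step.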